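Methyl removed from an oxygen: what to expect

The source may report more compounds than this note shows. Statements on the series, on what has been measured and on what is new or still open speak of the compounds shown alone.

Measured so far:
- compound 1 `COc1ccc(C(=O)/C=C/c2cc(OC)c(OC)cc2OC)cc1`: 2.07 ug/mL
- compound 2 `COc1cc(OC)c(OC)cc1/C=C/C(=O)c1cc(Cc2ccccc2)cc(Cc2ccccc2)c1`: 2.09 ug/mL
- compound 3 `COc1cc(C(=O)/C=C/c2cc(OC)c(OC)cc2OC)ccc1O`: 2.46 ug/mL

All three compounds were tested in a functional assay, read by Griess assay, with a stated time of 2.5 h; a lower number here means a stronger inhibitor, a higher number a weaker inhibitor. Going by the values given here, compound 1 gives the lowest of the three numbers, but the gaps to compound 2 and compound 3 are both within the scatter of repeated measurements, so no compound can be called stronger or weaker than another on these data; the three simply sit together. Compound 3, which already carries a hydroxy group on one of its rings, behaves no differently from the others.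

The next compound, compound 4 `COc1cc(OC)c(OC)cc1/C=C/C(=O)c1ccc(O)cc1`, has not yet been measured in this assay. It differs from compound 1 in one place: hydrogen in place of methyl on an oxygen on an aromatic ring. No measured pair shows this exact change, so the expectation must rest on the three numbers shown, which lie close together. The step from compound 1 to compound 4 is expected to be a 1.1-fold higher number from compound 1 to compound 4 (0.05 log units; within the scatter), that is, nothing beyond the scatter. Compound 4 is therefore estimated at 2.3 ug/mL, within a range from 1.2 ug/mL to 4.5 ug/mL.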

Compound 4, half-maximal inhibitory concentration: 2.5 ug/mL
For compound 4 the middle estimate is 1.1-fold (0.04 log units) below the measured one; the measured number falls inside the stated range.
By their numbers in this assay, from the lowest: compounds 1, 2, 3 and 4 (each within the scatter of the next).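

In this assay hydrogen in place of methyl on an oxygen on an aromatic ring gives a 1.2-fold higher number from compound 1 to compound 4 (0.08 log units; within the scatter) and so leaves the number within the scatter: on this pair, the methoxy and the hydroxy cannot be told apart. The second pair adds a different change, hydrogen in place of methoxy on an aromatic carbon, and it gives a 1.0-fold higher number from compound 3 to compound 4 (0.01 log units; within the scatter) with the same outcome, so this extra methoxy cannot be told from a plain hydrogen either. No measurement here offers a reason for either result.

From the compounds shown here alone, whether an ethyl or a longer chain on this oxygen, or an amine in its place, would move the number beyond the scatter stays open. Since every compound shown sits within the scatter of the next, none of these changes yet marks a part of the structure that the number depends on.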